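A few compounds are considered here, and "the series" means these few. Any claim that something is new, unique, unknown or untested is made for them only; others in the source may bear on it.

Measured so far in a functional assay on A2780 cells (Homo sapiens) for cytotoxicity; on this read-out lower numbers stand for stronger inhibition and higher numbers for weaker inhibition:
compound 1 `CC(=O)Nc1ncc(SCc2ncc(C(C)(C)C)o2)s1`: 50 nM
compound 2 `C[C@@H](C(=O)Nc1ncc(SCc2ncc(C(C)(C)C)o2)s1)c1ccccc1`: 900 nM
compound 3 `CC(C)(C)c1cnc(CSc2cnc(NC(=O)OCc3ccccc3)s2)o1`: 1040 nM

Compound 1 holds the lowest number of the three. Its nearest neighbour is compound 2, reached by an 18-fold higher number from compound 1 to compound 2 (1.26 log units; beyond the scatter), and the furthest is compound 3, reached by a 21-fold higher number from compound 1 to compound 3 (1.32 log units; beyond the scatter); the two larger compounds sit close together, as a 1.2-fold higher number from compound 2 to compound 3 (0.06 log units; within the scatter) shows.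

Compound 4 `CCNC(=O)Nc1ncc(SCc2ncc(C(C)(C)C)o2)s1` has not yet been measured in this assay. It departs from compound 1 at the same place as compounds 2 and 3 do: ethylamino in place of methyl on a carbonyl carbon. The two measured steps from this position both replaced methyl, once with 1-phenylethyl and once with benzyloxy, and both cost a lot. The ethylamino group of compound 4 is smaller than either of those and brings a hydrogen-bond donor that neither of them has, so the measured steps set a ceiling on what a change here has cost rather than a direct precedent.

He therefore expects compound 4 to lose some potency against compound 1, though less than compounds 2 and 3 did. For compound 4 the expected step is a 4.0-fold higher number from compound 1 to compound 4 (0.60 log units; beyond the scatter). For compound 4 in this assay the estimate is 200 nM, with a range from 60 nM to 700 nM.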

Compound 4, half-maximal inhibitory concentration: 120 nM
Beside the measured number, compound 4's estimate is 1.7-fold (0.22 log units) above it; the measured number falls inside the stated range.
By their numbers in this assay, from the lowest: compound 1; then compound 4; then compounds 2 and 3 (each within the scatter of the next).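

In this assay, this result shows that replacing the methyl on the carbonyl carbon need not bring a large loss: ethylamino gives a 2.4-fold higher number from compound 1 to compound 4 (0.38 log units; beyond the scatter), a modest step, though still one beyond the scatter. The earlier compounds shown here showed only large losses at this position, and ethylamino now separates clearly from both of those replacements, with an 8.7-fold lower number from compound 3 to compound 4 (0.94 log units; beyond the scatter) and a 7.5-fold lower number from compound 2 to compound 4 (0.88 log units; beyond the scatter), so the position responds to the choice of group and not merely to any departure from methyl. Methyl still gives the lowest number of the four, and nothing available explains these differences in terms of a measured property of the groups.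

What the compounds shown leave open is whether the ethyl chain or the nitrogen that links it to the carbonyl carbon accounts for the position of compound 4, since the step to ethylamino brings in both at once. A propyl group, which keeps the chain but has no such nitrogen, and a methylamino group, which keeps the nitrogen on a shorter chain, would bear on that question, and a dimethylamino group would show what happens when the amide hydrogen is gone.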